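Shortening the amide chain on the shared core

The source may hold more compounds than are shown below. What is called first, only, known or untested is meant among the compounds shown, and "the series" means these compounds.

Three compounds share one core and differ only in the group carried by the amide nitrogen. Compound 1 `O=C(CN1C(=O)/C(=C/c2ccc(-c3ccc(Cl)cc3)o2)SC1=S)NCc1ccc(C(F)(F)F)cc1` gives 155000 nM in a functional assay on K562 cells (Homo sapiens) for cytotoxicity, read by MTT assay, with a stated time of 72 h; on this read-out lower numbers stand for stronger inhibition and higher numbers for weaker inhibition. Compound 2 `O=C(CN1C(=O)/C(=C/c2ccc(-c3ccc(Cl)cc3)o2)SC1=S)NCc1ccccc1Cl` gives 64000 nM in this assay, a step of a 2.4-fold lower number from compound 1 to compound 2 (0.38 log units; beyond the scatter). Compound 3 `CCCCCCNC(=O)CN1C(=O)/C(=C/c2ccc(-c3ccc(Cl)cc3)o2)SC1=S` gives 50000 nM in this assay and stands at the lowest of the three numbers; the step from compound 1 is a 3.1-fold lower number from compound 1 to compound 3 (0.49 log units; beyond the scatter), while the step from compound 2 is a 1.3-fold lower number from compound 2 to compound 3 (0.11 log units; within the scatter), so compound 2 and compound 3 cannot be told apart on these numbers.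

Compound 4 `CCCNC(=O)CN1C(=O)/C(=C/c2ccc(-c3ccc(Cl)cc3)o2)SC1=S` has not yet been measured. It differs from compound 3 by hydrogen in place of propyl on a saturated chain carbon, three bonds along the chain from an amide-type nitrogen. Going by the values given here, none of the measured steps shortens a chain; each exchanges the whole group on the carbon bound to the amide nitrogen, and the one exchange of a chain for a ring, pentyl for 2-chlorophenyl, gave a 1.3-fold lower number from compound 2 to compound 3 (0.11 log units; within the scatter). Among the compounds with values here, no measured step therefore bears directly on this change, and no step beyond the scatter is expected in this assay from compound 3 to compound 4, in either direction. Compound 4 is expected to give 60000 nM in this assay, with a range from 25000 nM to 150000 nM. That estimate means an expected step of a 1.2-fold higher number from compound 3 to compound 4 (0.08 log units; within the scatter), which is expected to lie within the scatter.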

Compound 4, half-maximal inhibitory concentration: 50000 nM
For compound 4 the middle estimate is 1.2-fold (0.08 log units) above the measured one; measured number inside the range.
By their numbers in this assay, from the lowest: compounds 3, 4 and 2 (each within the scatter of the next); then compound 1.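

Notes on the amide chain: in this assay the cut from hexyl to propyl gives no change at the digits printed from compound 3 to compound 4 (within the scatter) and is the first shortening of a chain in the series, so across these two chains the number does not follow chain length. The shorter chain also keeps the standing of the longer one against the two ring-bearing amides: a 1.3-fold lower number from compound 2 to compound 4 (0.11 log units; within the scatter) leaves compound 4 indistinguishable from compound 2, while a 3.1-fold lower number from compound 1 to compound 4 (0.49 log units; beyond the scatter) keeps it clear of compound 1, just as compound 3 stands to those two compounds. Nothing on hand explains why the chain can be shortened with no visible effect on the number.

Open, on these data alone, is whether this flat response continues to a methyl or an ethyl on the amide nitrogen, or to a longer chain than hexyl, and whether a chain carrying an amine or a carboxylic acid would leave the number equally unmoved. Also open, as far as these compounds go, is whether compound 3 and compound 4 would remain indistinguishable on cells other than those used here.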